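The source may report more compounds than this note shows. Statements on the series, on what has been measured and on what is new or still open speak of the compounds shown alone.

Working notes on the series built on the shared core of compound 1 `CC(Cn1ncccc1=O)C(=N)S`, all read in a functional assay on the whole organism (stomach) with Rattus norvegicus as the target; on this read-out higher numbers stand for an effect only at larger amounts of compound and lower numbers for an effect already at smaller amounts. For compound 1 this assay returns only a limit, > 100 mg/kg. Compound 2 `CC/N=C(\S)CCn1nc(-c2ccccc2)ccc1=O` gives 100 mg/kg in this assay. For compound 3 `N=C(S)CCCCn1nc(-c2ccccc2)ccc1=O` this assay again returns only a limit, > 100 mg/kg. Among the compounds with values here, the single step that can be compared, a number no lower from compound 2 to compound 3 (the limit leaves the size open), is open in size and runs no lower. The point the limit of > 100 mg/kg in this assay, at which 2 of the 3 values shown sit, is where most of the series sits, so little spread is visible anywhere in these numbers.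

Compound 4 `CC(Cn1nc(-c2ccccc2)ccc1=O)C(=N)S` differs from compound 3 by a group of 5 heavy atoms (3 carbon, 1 nitrogen, 1 sulfur; no ring) in place of a group of 6 heavy atoms (4 carbon, 1 nitrogen, 1 sulfur; no ring), on a saturated chain carbon bound to an aromatic nitrogen. This carries the branched shorter side chain of compound 1 onto the core of compound 3. Within the data shown here, no measured step mirrors this change directly, and the one measured step of a number no lower from compound 2 to compound 3 (the limit leaves the size open) does not reach a number. With compound 3 standing at a limit and compound 1 at a limit as well, no step beyond the scatter is expected, a number no higher from compound 3 to compound 4 (the limit leaves the size open). The estimate for compound 4 in this assay is 100 mg/kg, within 40 mg/kg to 300 mg/kg, with a good chance that only a limit is reported.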

Compound 4, dose for half-maximal effect: 28.1 mg/kg
Beside the measured number, compound 4's estimate is 3.6-fold (0.55 log units) above it, outside the stated range (below it).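

On this saturated chain carbon bound to an aromatic nitrogen, the group of 5 heavy atoms separates from the groups of 6 heavy atoms in this assay while the phenyl stays in place, giving an at least 3.5-fold lower number from compound 3 to compound 4 (0.55 log units; beyond the scatter) and a 3.6-fold lower number from compound 2 to compound 4 (0.55 log units; beyond the scatter) in the two comparisons. With the group of 5 heavy atoms held fixed, phenyl in place of hydrogen on an aromatic carbon gives an at least 3.5-fold lower number from compound 1 to compound 4 (0.55 log units; beyond the scatter) as well. Compound 4 thus shows that a change at either place can move the read-out beyond the scatter, which the earlier values of compound 1, compound 2 and compound 3 could not show.

On these data alone, whether an amine, a carboxylic acid or a longer chain at this saturated chain carbon would keep the lower number remains open. The steps from compound 1 and compound 3 also stay without a full size because both compounds stand at a limit: the limit of > 100 mg/kg in this assay, at which 2 of the 4 values shown sit.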